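Swapping the amide-side aryl group: compound 4 expected

The source may report more compounds than this note shows. Statements on the series, on what has been measured and on what is new or still open speak of the compounds shown alone.

Measured compounds in a functional assay on MGC-803 cells (Homo sapiens) for inhibition, read by MTT assay, with a stated time of 72 h; on this read-out lower numbers stand for stronger inhibition and higher numbers for weaker inhibition:
- compound 1, `O=C(CSc1nc(Nc2ccccc2)c2ccccc2n1)Nc1ccccc1Cl`: 24800 nM
- compound 2, `O=C(CSc1nc(Nc2ccccc2)c2ccccc2n1)Nc1cccc(Cl)c1`: 14300 nM
- compound 3, `CCc1cccc(NC(=O)CSc2nc(Nc3ccccc3)c3ccccc3n2)c1`: 15800 nM

Compound 1 stands at the top of the three numbers in this assay, yet neither step away from it reaches beyond the scatter: a 1.7-fold lower number from compound 1 to compound 2 (0.24 log units; within the scatter) and a 1.6-fold lower number from compound 1 to compound 3 (0.20 log units; within the scatter). Between the two other compounds the step is smaller still: a 1.1-fold higher number from compound 2 to compound 3 (0.04 log units; within the scatter). All three compounds share the same core and differ only in the aryl group on the amide-type nitrogen.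

Compound 4, `COc1cccc(NC(=O)CSc2nc(Nc3ccccc3)c3ccccc3n2)c1`, has not been measured. Compared with compound 1 it carries 3-methoxyphenyl in place of 2-chlorophenyl on an amide-type nitrogen. The two steps that bear on this change are the ones from compound 1 to compounds carrying a 3-chlorophenyl or a 3-ethylphenyl group in the same place, and both stayed within the scatter. A third group on the same position gives no ground to expect anything larger, so the step to compound 4 is expected to be a modest lowering at most, a 1.6-fold lower number from compound 1 to compound 4 (0.19 log units; within the scatter), in line with the steps to compound 2 and compound 3.

Compound 4 is therefore estimated at 16000 nM, with a range from 7000 nM to 36000 nM in this assay.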

Compound 4, half-maximal inhibitory concentration: 10000 nM
Compound 4: the middle estimate sits 1.6-fold (0.20 log units) above what was measured; measured number inside the range.
By their numbers in this assay, from the lowest: compounds 4, 2, 3 and 1 (each within the scatter of the next, the first and the last beyond it).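

In this assay, within the data shown here, this change gives a 2.5-fold lower number from compound 1 to compound 4 (0.39 log units; beyond the scatter), the first step on this amide-type nitrogen to pass beyond the scatter, so replacing the 2-chlorophenyl group can shift the number measurably here, though only modestly. The 3-substituted groups themselves remain unseparated, as methoxy in place of ethyl gives a 1.6-fold lower number from compound 3 to compound 4 (0.20 log units; within the scatter) and methoxy in place of chloro gives a 1.4-fold lower number from compound 2 to compound 4 (0.16 log units; within the scatter), both within the scatter, and only compound 4 stands clearly apart from compound 1, while compound 2 and compound 3 do not. Nothing measured for these compounds accounts for this shift.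

These compounds leave open whether 2-methoxyphenyl would behave like the 2-chlorophenyl group of compound 1 or like the 3-methoxyphenyl group of compound 4, which would help separate the effect of the group's place from that of its identity. They also leave open what an amine, a carboxylic acid or a longer chain such as butoxy on this aryl ring would do, and whether any such group could carry the number further than the modest step seen so far.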